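Urea to amide in an acyl-CoA:cholesterol acyltransferase series

A few compounds are considered here, and "the series" means these few. Any claim that something is new, unique, unknown or untested is made for them only; others in the source may bear on it.

Measured compounds:
compound 1, `CCCCNC(=O)Nc1c(OCCCn2cnc(-c3ccccc3)c2)cccc1N(C)C`, 140 nM
compound 2, `CCCCCNC(=O)Nc1c(OCCCn2cnc(-c3ccccc3)c2)cccc1N(C)C`, 31 nM

In an assay for inhibition of acyl-CoA:cholesterol acyltransferase (Oryctolagus cuniculus), using microsomes (a lower number here means a stronger inhibitor, a higher number a weaker inhibitor), compound 1 gives the higher of the two numbers; its nearest neighbour is compound 2, with a 4.5-fold lower number from compound 1 to compound 2 (0.65 log units; beyond the scatter). Compound 3, `CCCCCC(=O)Nc1c(OCCCn2cnc(-c3ccccc3)c2)cccc1N(C)C`, differs from compound 1 by pentyl in place of butylamino on a carbonyl carbon. For the measured compounds named here, the only measured step, from compound 1 to compound 2, lengthens the chain and leaves the urea intact, so it does not bear directly on this change. Going by the values given here, with no step touching the carbonyl substituent, compound 3 is expected near compound 1, at 150 nM (range 40 nM to 600 nM), an expected 1.1-fold higher number from compound 1 to compound 3 (0.03 log units; within the scatter).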

Compound 3, half-maximal inhibitory concentration: 200 nM
Compound 3: the middle estimate sits 1.3-fold (0.12 log units) below what was measured, within the range that was stated.
By their numbers in this assay, from the lowest: compound 2; then compounds 1 and 3 (each within the scatter of the next).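

Read through this assay, the first direct test of this carbonyl substituent shows that pentyl can stand in place of butylamino with a 1.4-fold higher number from compound 1 to compound 3 (0.15 log units; within the scatter), so losing this urea nitrogen and its hydrogen-bond donor leaves the number within the scatter. Set against the longer urea, pentyl in place of pentylamino gives a 6.5-fold higher number from compound 2 to compound 3 (0.81 log units; beyond the scatter), so the outcome of the change depends on which urea it is compared with. Nothing shown here accounts for either step. Still open, as far as these compounds go, is whether a hexyl chain on the carbonyl carbon would lower the number in the amide as pentylamino did in the urea. A butoxy group at this position is also untested in the compounds shown.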